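Adding Fluoro to Compound 1: An Expected Small Step

A few compounds are considered here, and "the series" means these few. Any claim that something is new, unique, unknown or untested is made for them only; others in the source may bear on it.

For the measured compounds named here, in a functional assay on HeLa cells (Homo sapiens) for cytotoxicity, read by MTT assay, with a stated time of 72 h (on this read-out lower numbers stand for stronger inhibition and higher numbers for weaker inhibition), compound 1 `Cn1ccc2c(Oc3ccc(NC(=O)c4cc5cccnc5n(-c5ccc(Cl)cc5)c4=O)cc3)ncnc21` gives 49900 nM, the lowest of the three numbers measured so far. Compound 2 `Cn1ccc2c(Oc3ccc(NC(=O)c4cc5cccnc5n(-c5ccc(C(F)(F)F)cc5Cl)c4=O)cc3)ncnc21` gives 174000 nM, and compound 3 `Cn1ccc2c(Oc3ccc(NC(=O)c4cc5cccnc5n(-c5ccc(C(F)(F)F)c(Cl)c5)c4=O)cc3)ncnc21` gives 289000 nM. Compound 4 `Cn1ccc2c(Oc3ccc(NC(=O)c4cc5cccnc5n(-c5ccc(Cl)cc5)c4=O)cc3F)ncnc21` differs from compound 1 by one change: fluoro in place of hydrogen on an aromatic carbon. The measured steps, a 3.5-fold higher number from compound 1 to compound 2 (0.54 log units; beyond the scatter) and a 5.8-fold higher number from compound 1 to compound 3 (0.76 log units; beyond the scatter), are modest, but both replace the 4-chlorophenyl on an aromatic nitrogen. Going by the values given here, no measured step tests fluoro, so they bear on it only weakly, and no step beyond the scatter is expected in this assay. The expected result is a 1.0-fold higher number from compound 1 to compound 4 (0.02 log units; within the scatter). For compound 4 the estimate is 52000 nM, with an expected range of 22000 nM to 120000 nM.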

Compound 4, half-maximal inhibitory concentration: 43900 nM
The estimate for compound 4 lay 1.2-fold (0.07 log units) above the measured number; the range from low to high includes it.
By their numbers in this assay, from the lowest: compounds 4 and 1 (each within the scatter of the next); then compounds 2 and 3 (each within the scatter of the next).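

In this assay fluoro in place of hydrogen on an aromatic carbon gives a 1.1-fold lower number from compound 1 to compound 4 (0.06 log units; within the scatter) and so shows that this site, ortho to a large group and meta to a large group, takes a fluoro with no change beyond the scatter. Of the steps shown, this is the only one on this ring; the others all lie on the group on the aromatic nitrogen. No measured evidence bears on this result. Going by these compounds, whether a chloro, a methoxy or an amine at this site would behave the same stays open, as does fluoro on the other carbons of this ring.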